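The source may report more compounds than this note shows. Statements on the series, on what has been measured and on what is new or still open speak of the compounds shown alone.

In an ADME assay on Raji cells (Homo sapiens) for cytotoxicity, read by CellTiter-Glo and resazurin assay, with a stated time of 72 h (on this read-out higher numbers stand for an effect only at larger amounts of compound and lower numbers for an effect already at smaller amounts), compound 2 `CC(C)N(Cc1cccc(OCCCCCC(=O)O)c1)C(=O)c1ccc(-c2ccncc2)cc1` gives only a limit of the assay, > 26000 nM. Compound 1 `CC(C)N(Cc1cccc(OCCCCCC(=O)O)c1)C(=O)c1ccc(-c2cccc3ccccc23)cc1` likewise gives a limit, > 26000 nM. Compound 3 `CC(=O)c1cccc(-c2ccc(C(=O)N(Cc3cccc(OCCCCCC(=O)O)c3)C(C)C)cc2)c1` also gives a limit, > 26000 nM. All three results sit at the same place, (the limit of > 26000 nM in this assay, at which 3 of the 3 values shown sit), so compound 2 cannot be set apart from the other two on the numbers shown. The change to compound 4 `CCOc1cccc(-c2ccc(C(=O)N(Cc3cccc(OCCCCCC(=O)O)c3)C(C)C)cc2)c1` is 3-ethoxyphenyl in place of pyridin-4-yl on an aromatic carbon. Within the data shown here, two measured steps bear on this change, a step that the two limits leave unreadable from compound 2 to compound 3 and a step that the two limits leave unreadable from compound 1 to compound 2, and both remain unreadable because the values on either side of each sit at the limit (the limit of > 26000 nM in this assay, at which 3 of the 3 values shown sit). Neither size nor direction can be taken from them, and the shown compounds give no case of a number below that limit. Among the measured compounds shown here, since every compound measured so far sits at the limit, compound 4 is expected to behave the same way, with an estimated value of 26000 nM and a range from 15000 nM to 60000 nM. The step this estimate implies is expected to be a number no higher from compound 2 to compound 4 (the limit leaves the size open).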

Compound 4, half-maximal effective concentration: > 20800 nM
Compound 4 gave a limit, no number; the forecaster's own chance of this, stated with the estimate: 85%; the middle value is on the limit's open side.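

Compound 4, like compound 1, compound 2 and compound 3, gives only a limit in this assay, so none of its steps from those three compounds can be read. The compounds shown leave open what actual number any of them would give, and whether changing the group on that aromatic carbon shifts it at all.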